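From chloromethyl to phenyl on a carbonyl carbon

The source may hold more compounds than are shown below. What is called first, only, known or untested is meant among the compounds shown, and "the series" means these compounds.

Measured in a functional assay on cells (Endothelial cell, Sus scrofa) for antiproliferative activity (a higher number here means a weaker inhibitor, a lower number a stronger inhibitor), so far:
Compound 1 `CO[C@@H]1[C@H](OC(=O)NC(=O)CCl)CO[C@]2(COC(C)(C)O2)[C@@]1(O)C1(C)CO1` – 57000 nM
Compound 2 `CO[C@@H]1[C@H](OC(=O)NC(=O)CCl)CO[C@]2(COC(C)(C)O2)[C@@]1(OC)C1(C)CO1` – 175000 nM
Compound 3 `CO[C@@H]1[C@H](OC(=O)NC(=O)CCl)CO[C@]2(COC(C)(C)O2)[C@@]1(O)C1OC1CC(C)C` – 124000 nM; 178000 nM (2 entries)

Compound 1 holds the lowest number here at 57000 nM and sits under both entries of compound 3. The closest measured neighbour is compound 2, and the step to it reads a 3.1-fold higher number from compound 1 to compound 2 (0.49 log units; beyond the scatter) in this assay and comes from methyl in place of hydrogen on an oxygen on a saturated carbon. Repeat measurements of one compound can spread, as seen in the several entries of compound 3 in this assay, 124000 nM; 178000 nM (2 entries) and this is worth keeping in mind when reading small differences.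

The next compound is compound 4 `CO[C@@H]1[C@H](OC(=O)NC(=O)c2ccccc2)CO[C@]2(COC(C)(C)O2)[C@@]1(O)C1(C)CO1` which has phenyl in place of chloromethyl on a carbonyl carbon while the rest of the core of compound 1 stays the same. Among the measured compounds shown here, no measured step changes this group. For the measured compounds named here, the one step available, a 3.1-fold higher number from compound 1 to compound 2 (0.49 log units; beyond the scatter) at another place in the molecule, is only a loose guide to size, so a modest change is the most that can be expected. As far as these compounds go, the expected step, leaning to a higher number with the direction still open, is a 1.8-fold higher number from compound 1 to compound 4 (0.24 log units; within the scatter) in this assay and remains uncertain. For compound 4 the estimated value is 100000 nM with an expected range from 25000 nM to 350000 nM as the measurement is awaited.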

Compound 4, half-maximal inhibitory concentration: 363000 nM
Beside the measured number, compound 4's estimate is 3.6-fold (0.56 log units) below it, outside the stated range (above it).
By their numbers in this assay, from the lowest: compound 1; then compound 2; then compound 4.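

Replacing chloromethyl with phenyl on the carbonyl carbon gives, in this assay, a 6.4-fold higher number from compound 1 to compound 4 (0.80 log units; beyond the scatter). Among the compounds shown here, this is the first measured change at this position, and it shows that the group on this carbonyl carbon matters to the read-out: the swap exchanges a small chlorine-bearing group for a six-membered aromatic ring, and the number rises. Compound 1 now stands lower than both of its neighbours with a listed step, the other being the change on the oxygen, a 3.1-fold higher number from compound 1 to compound 2 (0.49 log units; beyond the scatter), and this step too is printed as beyond the scatter, which repeat entries help to gauge: the several entries of compound 3 in this assay, 124000 nM; 178000 nM (2 entries)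

As far as these compounds go, the swap removes the chlorine and adds the ring in a single move, so whether the higher number goes with the loss of one or the arrival of the other stays open. A plain methyl or a bromomethyl group on this carbonyl carbon would pull the two apart, and a benzyl group would show how the ring behaves when set one carbon further out.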